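A few compounds are considered here, and "the series" means these few. Any claim that something is new, unique, unknown or untested is made for them only; others in the source may bear on it.

Measured compounds:

compound 1 `Cc1ccccc1-n1cc(-c2cccc(NS(=O)(=O)c3c[nH]c(=O)[nH]c3=O)c2)nn1`: 15300 nM
compound 2 `Cc1cccc(-n2cc(-c3cccc(NS(=O)(=O)c4c[nH]c(=O)[nH]c4=O)c3)nn2)c1`: 28300 nM
compound 3 `Cc1ccccc1-n1cc(-c2ccc(NS(=O)(=O)c3c[nH]c(=O)[nH]c3=O)cc2)nn1`: "not toxic" (no number reported)

In an ADME assay on L02 cells (Homo sapiens) for cytotoxicity, read by MTT assay, with a stated time of 24 h (on this read-out lower numbers stand for higher toxicity in this test and higher numbers for lower toxicity in this test), compound 1 gives 15300 nM and compound 2 gives 28300 nM. The change between them is 3-methylphenyl in place of 2-methylphenyl on an aromatic nitrogen and the step is a 1.8-fold higher number from compound 1 to compound 2 (0.27 log units; within the scatter). The two values therefore stand within the scatter of one another, and no order between compound 1 and compound 2 is drawn from them.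

Compound 3 carries a different core from compound 1; the difference between the two cores is not broken down here. For compound 3 no number was obtained in this assay; compound 3 is recorded as "not toxic" (no number reported).

Compound 4 `Cc1cccc(-n2cc(-c3ccc(NS(=O)(=O)c4c[nH]c(=O)[nH]c4=O)cc3)nn2)c1` is not yet measured. It differs from compound 3 by 3-methylphenyl in place of 2-methylphenyl on an aromatic nitrogen. The place of this change is the same, word for word, as the place of the change from compound 1 to compound 2, so it is the same change, seen here for the second time in the series.

Among the measured compounds shown here, the one earlier instance, from compound 1 to compound 2, gave a step within the scatter a 1.8-fold higher number from compound 1 to compound 2 (0.27 log units; within the scatter); on that rests the expectation that the same change on the core of compound 3 makes no step beyond the scatter either, so that compound 4 is expected to stand about where compound 3 stands, most likely again without a single number. Should a number be returned, compound 4 is estimated at 60000 nM in this assay, with an expected range from 20000 nM to 200000 nM.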

Compound 4, half-maximal cytotoxic concentration: 39000 nM
For compound 4 the middle estimate is 1.5-fold (0.19 log units) above the measured one; measured number inside the range.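

Among the compounds shown here, no step from compound 3 to compound 4 can be read: compound 4 gives 39000 nM but compound 3 is recorded without a single number. The compounds shown leave open whether 3-methylphenyl in place of 2-methylphenyl does the same on the core of compound 3 as on the core of compound 1. No evidence on this result is available.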